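A few compounds are considered here, and "the series" means these few. Any claim that something is new, unique, unknown or untested is made for them only; others in the source may bear on it.

Working notes on the series, read in a functional assay on MDA-MB-231 cells (Homo sapiens) for antiproliferative activity, read by sulforhodamine B assay, with a stated time of 72 h; on this read-out lower numbers stand for stronger inhibition and higher numbers for weaker inhibition. Compound 1 `CCOc1cc2occ(-c3csc4ccccc34)c(=O)c2c(OCC)c1OC` gives 1000 nM. Compound 2 `COc1c(OC(C)C)cc2oc(-n3cncn3)c(-c3csc4ccccc34)c(=O)c2c1OC(C)C` gives > 10000 nM, which is a limit of the assay and not a number. Compound 3 `O=C(/C=C/c1csc2ccccc12)c1ccccc1O` gives 5300 nM. That is the higher of the two actual numbers in the set, and compound 1, its nearest neighbour, lies lower by a margin beyond the usual scatter.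

Next in line is compound 4 `Cc1ccc(O)c(C(=O)/C=C/c2csc3ccccc23)c1`, which differs from compound 3 by a single change: methyl in place of hydrogen on an aromatic carbon. The new methyl sits on a six-membered aromatic ring of carbon only, meta to a large group and para to a hydroxy group.

Among the measured compounds shown here, no pair of measured compounds in this set differs in one place only, so the size of this change has no direct precedent. The anchor is compound 3 at 5300 nM. In this assay the expected outcome is no shift beyond the scatter, with no confident direction, and the estimated move is a 1.2-fold lower number from compound 3 to compound 4 (0.07 log units; within the scatter). For compound 4 the estimated value is 4500 nM, with an expected range from 1800 nM to 10000 nM.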

Compound 4, half-maximal inhibitory concentration: 6000 nM
Beside the measured number, compound 4's estimate is 1.3-fold (0.12 log units) below it; the measured number falls inside the stated range.
By their numbers in this assay, from the lowest: compound 1; then compounds 3 and 4 (each within the scatter of the next). At a limit, above all of these: compound 2.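

Among the compounds shown here, this is the first step that differs in one place only, and in this assay methyl in place of hydrogen on an aromatic carbon, para to a hydroxy group and meta to a large group, gives a 1.1-fold higher number from compound 3 to compound 4 (0.05 log units; within the scatter) and so leaves the read-out where it was. At this position of the six-membered aromatic ring of carbon only, one added carbon therefore produces no shift that can be told from the scatter, in either direction, and the change can be carried on this scaffold without a measurable penalty or gain. Nothing measured here bears on why the step is this small.

Going by these compounds, whether this position stays as tolerant for a group other than methyl remains open: an amine, a carboxylic acid or a longer alkyl chain at the same carbon could still move the number beyond the scatter. On these data alone, it is equally open whether the hydroxy group para to this carbon contributes to the read-out, since a methoxy group in its place would be needed to answer that.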